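Working notes: extending the chain of compound 1

This account rests on a few compounds, and the source may have more. Where it says the series, first, only, none or still open, it means among the compounds named here.

compound 1 `CCCCOc1ccc(-c2c(C)[nH]c(=O)n2C)cc1` gives 5100 nM
compound 2 `CCCCOc1ccc(-c2c(C)[nH]c(=O)n2C2CCCCC2)cc1` gives 13900 nM
compound 3 `CCCCc1ccc(-c2c(C)[nH]c(=O)n2Cc2ccccc2)cc1` gives 12400 nM

All three values come from a functional assay on brain (Rattus norvegicus, strain Wistar) for inhibition (a higher number here means a weaker inhibitor, a lower number a stronger inhibitor), and are half-maximal inhibitory concentrations. Compound 1 at 5100 nM has the lowest number of the three, and compound 3 and compound 2 both lie higher.

The next compound to be read is compound 4 `CCCCCOc1ccc(-c2c(C)[nH]c(=O)n2C)cc1`, which differs from compound 1 by methyl in place of hydrogen on a saturated chain carbon, four bonds along the chain from an oxygen on an aromatic ring.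

Among the measured compounds shown here, no measured step touches this chain. For the measured compounds named here, the only step available, a 2.7-fold higher number from compound 1 to compound 2 (0.44 log units; beyond the scatter), comes from cyclohexyl in place of methyl on an aromatic nitrogen, so it is a weak guide to a change elsewhere in the molecule. Even that larger replacement gave only a modest change. For the smaller chain change, no step beyond the scatter is expected in this assay, and no direction can be favoured. The estimated step is a 1.1-fold lower number from compound 1 to compound 4 (0.03 log units; within the scatter) and is expected to stay small. Compound 4 is expected at 4800 nM, with an estimated range from 2200 nM to 10500 nM as the measurement stands open.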

Compound 4, half-maximal inhibitory concentration: 4500 nM
The estimate for compound 4 lay 1.1-fold (0.03 log units) above the measured number; the range from low to high includes it.
By their numbers in this assay, from the lowest: compounds 4 and 1 (each within the scatter of the next); then compounds 3 and 2 (each within the scatter of the next).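

Methyl in place of hydrogen on a saturated chain carbon, four bonds along the chain from an oxygen on an aromatic ring, gives a 1.1-fold lower number from compound 1 to compound 4 (0.05 log units; within the scatter) in this assay. Among the compounds shown here, this is the first measured step on the chain itself, and it shows that this position accepts one more carbon with no change beyond the scatter, whereas the replacement on the aromatic nitrogen gave a 2.7-fold higher number from compound 1 to compound 2 (0.44 log units; beyond the scatter). No separate evidence bears on this result.

A single step cannot show whether the chain stays this flat over a longer run, as with a hexyl or octyl chain, or with an amine or a carboxylic acid at this position. It also leaves open whether the same chain change would read alike with cyclohexyl on the aromatic nitrogen.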